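Swapping the aryl on a hydrazide carbonyl in a dihydropyridine series

The compounds below may be only part of what the source reports. "The series", "measured", "known", "first", "only" and "open" are said of these compounds alone.

Measured so far:
Compound 1, `CCOC(=O)C1=C(C)NC(C)=C(C(=O)OCC)C1c1ccc(OCC(=O)Nc2c(C)cccc2C)cc1`, 15.9%
Compound 2, `CCOC(=O)C1=C(C)NC(C)=C(C(=O)OCC)C1c1ccc(OCC(=O)Nc2nc3ccccc3s2)cc1`, 47.7%
Compound 3, `CCOC(=O)C1=C(C)NC(C)=C(C(=O)OCC)C1c1ccc(OCC(=O)NNC(=O)c2ccc(C)cc2)cc1`, 16.7%

All three share one core and differ only in the group on the amide-type nitrogen of the side chain. In a functional assay on the whole organism (strain Wistar) for inhibition, with Rattus norvegicus as the target, read by paw edema, with stated times of 30 min and 0.5 h, at a dose of 20 mg/kg (on this read-out higher numbers stand for more inhibition at the one dose given (going by the name of the read-out) and lower numbers for less inhibition), compound 2 gives 47.7%, the highest number of the three, and the steps of a number 31.8 percentage points higher from compound 1 to compound 2 (beyond the scatter) and a number 31 percentage points lower from compound 2 to compound 3 (beyond the scatter) are both large. Compound 3 stands second highest, but its step from compound 1, a number 0.8 percentage points higher from compound 1 to compound 3 (within the scatter), is within the scatter, so compound 1 and compound 3 cannot be ranked against each other.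

Compound 4, `CCOC(=O)C1=C(C)NC(C)=C(C(=O)OCC)C1c1ccc(OCC(=O)NNC(=O)c2sccc2Cl)cc1`, has not yet been measured. It differs from compound 3 in one place: 3-chlorothiophen-2-yl in place of 4-methylphenyl on a carbonyl carbon. Said one bond further out, the ((4-methylphenyl)carbonyl)amino group becomes the ((3-chlorothiophen-2-yl)carbonyl)amino group. Going by the values given here, none of the measured steps touches this carbonyl carbon; the two large steps both concern the group on the amide-type nitrogen itself, and the only step that leaves that part of the side chain in a hydrazide form, from compound 1 to compound 3, is within the scatter. There is therefore no measured basis for expecting a step beyond the scatter in this assay. Compound 4 is expected to sit near compound 3, with an estimated step of a number 3.3 percentage points higher from compound 3 to compound 4 (within the scatter) and an estimated value of 20%, in a range from 8% to 38%.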

Compound 4, a percentage reported as inhibition, in the whole organism at one dose (the size of the read-out at that dose, not a potency): 10.6%
Compound 4: the middle estimate sits 9.4 percentage points above what was measured; the measured number falls inside the stated range.
By their numbers in this assay, from the lowest: compounds 4, 1 and 3 (each within the scatter of the next); then compound 2.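

In this assay, 3-chlorothiophen-2-yl in place of 4-methylphenyl on the carbonyl carbon gives (a number 6.1 percentage points lower from compound 3 to compound 4 (within the scatter)), so this ring exchange does not separate the two hydrazides. Compound 4 also cannot be told apart from the 2,6-dimethylphenyl amide (a number 5.3 percentage points lower from compound 1 to compound 4 (within the scatter)), while the 1,3-benzothiazol-2-yl amide stands clear of it (a number 37.1 percentage points lower from compound 2 to compound 4 (beyond the scatter)), so that large gap now holds against two different aryl hydrazides rather than one. No measurement here gives a reason for any of these numbers.

From the compounds shown here alone, what a chain on this carbonyl carbon would do stays open, whether a methyl group or a longer alkyl chain in place of the ring, or an amine or a carboxylic acid carried on it. Also open, going by these compounds, is whether 1,3-benzothiazol-2-yl on this carbonyl carbon would bring the hydrazides near compound 2.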